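The source may hold more compounds than are shown below. What is called first, only, known or untested is meant among the compounds shown, and "the series" means these compounds.

Three compounds measured so far in a functional assay on KB cells (Homo sapiens) for cytotoxicity, read by MTT assay, with a stated time of 72 h (on this read-out lower numbers stand for stronger inhibition and higher numbers for weaker inhibition), are shown here
compound 1 `O=S(=O)(c1ccccc1)c1nc2ccccc2nc1N1CCC(O)CC1` gives 5360 nM in this test
compound 2 `Cc1ccc(S(=O)(=O)c2nc3ccccc3nc2N2CCC(O)CC2)cc1` gives 6140 nM in this test
compound 3 `COc1ccc(S(=O)(=O)c2nc3ccccc3nc2N2CCC(O)CC2)cc1` gives 8060 nM in this test

Compound 3 at 8060 nM cannot be told apart from the other two compounds, as all three values lie within the scatter of one another. The unmeasured compound 4 `O=S(=O)(c1ccc(F)cc1)c1nc2ccccc2nc1N1CCC(O)CC1` has fluoro in place of methoxy on an aromatic carbon, para to a large group (fluoro in place of methoxy on an aromatic carbon). Going by the values given here, three measured steps bear on this change, all at that same place. They are a 1.1-fold higher number from compound 1 to compound 2 (0.06 log units; within the scatter) for methyl in place of hydrogen, a 1.5-fold higher number from compound 1 to compound 3 (0.18 log units; within the scatter) for methoxy in place of hydrogen, and a 1.3-fold higher number from compound 2 to compound 3 (0.12 log units; within the scatter) for methoxy in place of methyl. None of these compounds carries fluoro, so the evidence is indirect. Among these three compounds, however, no change at this place has moved the number beyond the scatter. On these data alone, with a 1.5-fold higher number from compound 1 to compound 3 (0.18 log units; within the scatter) as the closest guide, no step beyond the scatter is expected in this assay for the new change, and the direction stays open. The expected result is a 1.3-fold lower number from compound 3 to compound 4 (0.13 log units; within the scatter) as an estimate that leaves compound 4 among the other values. For compound 4 the estimated value is 6000 nM with an expected range from 3200 nM to 11000 nM in this test.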

Compound 4, half-maximal inhibitory concentration: 9580 nM
For compound 4 the middle estimate is 1.6-fold (0.20 log units) below the measured one, and the stated range covers the measured number.
By their numbers in this assay, from the lowest: compounds 1, 2, 3 and 4 (each within the scatter of the next).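

In this assay, fluoro now joins hydrogen, methyl and methoxy on the aromatic carbon para to a large group, and it cannot be told apart from any of them: the test gives a 1.2-fold higher number from compound 3 to compound 4 (0.08 log units; within the scatter), a 1.6-fold higher number from compound 2 to compound 4 (0.19 log units; within the scatter) and a 1.8-fold higher number from compound 1 to compound 4 (0.25 log units; within the scatter). The earlier compounds shown here showed this flat picture only for hydrogen and two carbon-containing groups, whereas the new result extends it to a group with a different kind of atom, and even the step between compound 1 and compound 4 does not leave the scatter. So, across these four compounds, the choice of group at this place makes no difference that this test can resolve, and no measurement at hand offers an explanation for that.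

On these data alone, it remains open whether a group of another kind at this place, such as an amine, a carboxylic acid or a longer chain, would move the number beyond the scatter. All four compounds also share the rest of their structure, so they say nothing about how a change elsewhere in the shared core would affect the result.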